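Piperazine in place of piperidine on the chain

This account rests on a few compounds, and the source may have more. Where it says the series, first, only, none or still open, it means among the compounds named here.

Of the compounds shown here, three sharing one core have been measured in a toxicity assay on L02 cells (Homo sapiens) for cytotoxicity, read by MTT assay, with a stated time of 72 h; a lower number here means a stronger inhibitor, a higher number a weaker inhibitor. Compound 1 `O=C1c2c[n+]([O-])c3ccccc3c2C(=O)c2c1c1ccccc1n2Cc1cn([C@H]2C[C@H](O)[C@@H](CO)O2)nn1` gives 280 nM in this assay. Compound 2 `O=C1c2c[n+]([O-])c3ccccc3c2C(=O)c2c1c1ccccc1n2Cc1cn([C@@H]2C[C@H](O)[C@@H](CO)O2)nn1` gives 630 nM, and the step of a 2.3-fold higher number from compound 1 to compound 2 (0.35 log units; beyond the scatter) rests only on (the fact that compounds 1 and 2 differ only in the configuration as drawn). Compound 3 `O=C1c2c[n+]([O-])c3ccccc3c2C(=O)c2c1c1ccccc1n2CCCCN1CCCCC1` gives 610 nM in this assay, the second highest of the three numbers: it sits within the scatter of compound 2 and beyond it from compound 1.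

Compound 4 `CCCN1CCN(CCCCn2c3c(c4ccccc42)C(=O)c2c[n+]([O-])c4ccccc4c2C3=O)CC1` has not yet been measured. It differs from compound 3 by 4-propylpiperazin-1-yl in place of piperidin-1-yl on a saturated chain carbon, four bonds along the chain from an aromatic nitrogen. Going by the values given here, no measured step concerns a change of this kind; the one step on record, a 2.3-fold higher number from compound 1 to compound 2 (0.35 log units; beyond the scatter), is a change of configuration alone, so it offers no guide to a swap of one saturated ring for another on the chain. The expectation for this assay is therefore a step of no clear direction, most likely within the scatter, written as a 1.1-fold higher number from compound 3 to compound 4 (0.06 log units; within the scatter). Compound 4 is estimated at 700 nM in this assay, with a range from 250 nM to 2000 nM.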

Compound 4, half-maximal inhibitory concentration: 6830 nM
The estimate for compound 4 lay 9.8-fold (0.99 log units) below the measured number; measured number above the stated range.
By their numbers in this assay, from the lowest: compound 1; then compounds 3 and 2 (each within the scatter of the next); then compound 4.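

The group at the end of the chain proves far from neutral in this assay: 4-propylpiperazin-1-yl in place of piperidin-1-yl, on a saturated chain carbon four bonds along the chain from an aromatic nitrogen, gives an 11-fold higher number from compound 3 to compound 4 (1.05 log units; beyond the scatter). This step is larger than the only earlier one, a 2.3-fold higher number from compound 1 to compound 2 (0.35 log units; beyond the scatter), so the group on this chain can move the number further than the configuration change did. Nothing measured here gives a cause for the new step.

The change adds a second ring nitrogen and a propyl group together, so the compounds shown cannot say which of the two goes with the higher number. An unsubstituted piperazin-1-yl, a 4-methylpiperazin-1-yl or a morpholin-4-yl on the same chain could separate these two parts of the change.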